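This account rests on a few compounds, and the source may have more. Where it says the series, first, only, none or still open, it means among the compounds named here.

Compound 1 `CC1=C(/C=C/C(=O)/C=C/c2ccccc2Cl)C(C)(C)CCC1` gives 21800 nM in a functional assay on HeLa cells (Homo sapiens) for cytotoxicity, read by sulforhodamine B assay, with a stated time of 48 h; on this read-out lower numbers stand for stronger inhibition and higher numbers for weaker inhibition. Compound 2 `CC1=C(/C=C/C(=O)/C=C/c2ccccc2C)C(C)(C)CCC1` is reported in this assay only as the limit > 100000 nM. For the measured compounds named here, the single measured step, an at least 4.5-fold higher number from compound 1 to compound 2 (0.66 log units; beyond the scatter), is bounded by the limit of > 100000 nM in this assay, at which 1 of the 2 values shown sits, so compound 2 stands at the weak end of what this assay can report. Compound 3 `CC1=C(/C=C/C(=O)/C=C/c2cccnc2)C(C)(C)CCC1` differs from compound 2 by pyridin-3-yl in place of 2-methylphenyl on a double-bonded chain carbon bound to a double-bonded chain carbon. Going by the values given here, no measured step concerns an exchange of one aromatic ring for another, so the chloro-to-methyl step offers only indirect guidance, and the move from compound 2 to compound 3 is expected to give an at least 2.0-fold lower number from compound 2 to compound 3 (0.30 log units; that floor lies within the scatter). Compound 3 is therefore estimated at 50000 nM, between 12000 nM and 200000 nM.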

Compound 3, half-maximal inhibitory concentration: 17400 nM
For compound 3 the middle estimate is 2.9-fold (0.46 log units) above the measured one, within the range that was stated.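

Compound 3 shows that this position on the double-bonded chain carbon accepts a ring with a hetero atom, with an at least 5.7-fold lower number from compound 2 to compound 3 (0.75 log units; beyond the scatter) in this assay. Compound 2 is only a limit, so that step is a floor: the limit of > 100000 nM in this assay, at which 1 of the 3 values shown sits. Against the chloro-bearing ring the result is a 1.3-fold lower number from compound 1 to compound 3 (0.10 log units; within the scatter), so compound 1 and compound 3 cannot be told apart here.

As far as these compounds go, whether the ring nitrogen or merely the loss of the methyl group drives the step remains open, and a plain phenyl ring would separate the two. From the compounds shown here alone, how an amine on the ring would read is also open.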